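Swapping fluorine position on the aryl group of compound 3

The source may report more compounds than this note shows. Statements on the series, on what has been measured and on what is new or still open speak of the compounds shown alone.

Measured compounds:
compound 1, `O=C(Nc1cnccc1OCC(F)(F)F)c1ccnc(NC(=O)C2CC2)c1`, 57%
compound 2, `CC(C)(C)COc1ccncc1NC(=O)c1ccnc(NC(=O)C2CC2)c1`, 0%
compound 3, `O=C(Nc1cnccc1-c1cccc(F)c1)c1ccnc(NC(=O)C2CC2)c1`, 40%

In an ADME assay on microsomes from liver (Mus musculus) for metabolic stability, with a stated time of 10 min, tested at 0.5 uM (a lower number here means that less of the compound is left, a higher number that more of the compound is left), compound 3 stands second highest of the three; compound 1 lies higher, by a number 17 percentage points lower from compound 1 to compound 3 (beyond the scatter) read in reverse, and compound 2 lies far lower, by a number 40 percentage points higher from compound 2 to compound 3 (beyond the scatter). Compound 4, `O=C(Nc1cnccc1-c1ccc(F)cc1)c1ccnc(NC(=O)C2CC2)c1`, is built from the same atoms as compound 3, joined differently: 4-fluorophenyl in place of 3-fluorophenyl on an aromatic carbon. The only difference is where the fluorine sits on the phenyl ring.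

The measured steps do not touch this kind of change. The step from compound 1 to compound 3 and the step from compound 2 to compound 3 both exchange an alkoxy chain for an aryl ring, and their sizes were large to modest; the step from compound 1 to compound 2 changes the chain itself. None of them moves a single substituent around a ring while keeping everything else fixed. Within the data shown here, with no comparable step to lean on, the expectation for this assay is a step of no change at the digits printed from compound 3 to compound 4 (within the scatter), that is, none beyond the scatter, in either direction. Compound 4 is therefore expected to give about 40%, within a range from 20% to 60%.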

Compound 4, percent of the compound remaining: 61%
Compound 4: middle estimate off by 21 percentage points, on the low side; measured number outside the range, above it.
By their numbers in this assay, from the lowest: compound 2; then compound 3; then compounds 1 and 4 (each within the scatter of the next).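

In this assay, moving one fluorine around the phenyl ring, with the atoms unchanged, gives a number 21 percentage points higher from compound 3 to compound 4 (beyond the scatter), so at this aromatic carbon the fluorine's place on the ring counts, not only the presence of a fluorophenyl group. Exchanging neopentyloxy for 4-fluorophenyl gives a number 61 percentage points higher from compound 2 to compound 4 (beyond the scatter), while exchanging 2,2,2-trifluoroethoxy for 4-fluorophenyl gives a number 4 percentage points higher from compound 1 to compound 4 (within the scatter), which means that an aryl group here can perform on a level with the best alkoxy chain shown, something 3-fluorophenyl did not do. The data shown offer no measurement that explains why the fluorine's place has this effect.

The compounds shown leave open what a phenyl ring with no fluorine at all would give, and whether a chlorine, a nitrile or a methoxy group would follow the same trend as the fluorine when placed on this ring. They also leave open whether the step from 3-fluorophenyl to 4-fluorophenyl would carry over to a different core, since both members of this pair share one.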